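This account rests on a few compounds, and the source may have more. Where it says the series, first, only, none or still open, it means among the compounds named here.

Of the compounds shown here, three with a shared core have been measured in a functional assay on MCF7 cells (Homo sapiens) for cytotoxicity, read by neutral red uptake, with a stated time of 3 days (a higher number here means a weaker inhibitor, a lower number a stronger inhibitor), and they differ only in one group on an aromatic carbon. Compound 1 `Cc1c(F)c(N)c2c(=O)cc(-c3ccc(N)c(F)c3)oc2c1F`, with a methyl group there, gives 13 nM. Compound 2 `C[S+]([O-])c1c(F)c(N)c2c(=O)cc(-c3ccc(N)c(F)c3)oc2c1F`, with a sulfur-bearing group, gives 2500 nM. Compound 3 `COc1c(F)c(N)c2c(=O)cc(-c3ccc(N)c(F)c3)oc2c1F`, with methoxy, gives 100 nM, which places it in the middle: weaker than compound 1 and stronger than compound 2.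

Compound 4 `Nc1ccc(-c2cc(=O)c3c(N)c(F)c(CO)c(F)c3o2)cc1F` has the same atoms as compound 3, joined differently, with hydroxymethyl in place of methoxy on an aromatic carbon. Among the measured compounds shown here, no measured step makes this exact exchange, so the evidence is indirect. Replacing the methyl group gave a 7.7-fold higher number from compound 1 to compound 3 (0.89 log units; beyond the scatter), a modest step, and a 190-fold higher number from compound 1 to compound 2 (2.28 log units; beyond the scatter), a large one. Exchanging the sulfur-bearing group for methoxy gave a 25-fold lower number from compound 2 to compound 3 (1.40 log units; beyond the scatter), so the numbers move widely with the group on this carbon. Both replacements of methyl raised the number, which gives a weak hint of direction only. A moderate move towards a higher number is therefore expected in this assay, with real uncertainty. The estimated step is a 3.0-fold higher number from compound 3 to compound 4 (0.48 log units; beyond the scatter). For compound 4 the estimate is 300 nM, with an expected range from 60 nM to 1500 nM.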

Compound 4, half-maximal inhibitory concentration: 62 nM
Compound 4: the middle estimate sits 4.8-fold (0.68 log units) above what was measured, and the stated range covers the measured number.
By their numbers in this assay, from the lowest: compound 1; then compounds 4 and 3 (each within the scatter of the next); then compound 2.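

In this assay, exchanging methoxy for hydroxymethyl gives a 1.6-fold lower number from compound 3 to compound 4 (0.21 log units; within the scatter), so these two arrangements of the same atoms, which differ by one hydrogen-bond donor, cannot be told apart at this carbon. Adding hydroxy to the methyl group gives a 4.8-fold higher number from compound 1 to compound 4 (0.68 log units; beyond the scatter), while replacing the sulfur-bearing group with hydroxymethyl gives a 40-fold lower number from compound 2 to compound 4 (1.61 log units; beyond the scatter), which places both oxygen-bearing groups well clear of compound 2 yet leaves compound 1, with its plain methyl group, the strongest of the set. No measured property of these compounds is available to explain this order.

From the compounds shown here alone, it remains open whether other groups on this carbon, such as an aminomethyl group, a carboxylic acid or a longer chain like 2-hydroxyethyl, would stay close to compound 3 and compound 4 or come closer to compound 1. These compounds also leave open whether the close match between methoxy and hydroxymethyl would hold in a different cell line or over a different exposure time.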